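Swapping (oxolan-2-yl)methyl for 4-chlorophenyl on the shared core

This account rests on a few compounds, and the source may have more. Where it says the series, first, only, none or still open, it means among the compounds named here.

Measured in a functional assay (strain AB) with Danio rerio as the target, read by microscopy, with a stated time of 1 h; a lower number here means that less compound is needed, a higher number that more compound is needed for the effect:
- Compound 1 `CCN1CCc2c(sc(NC(=O)Nc3cccc(Cl)c3Cl)c2C(N)=O)C1`: 17400 nM
- Compound 2 `CCN1CCc2c(sc(NC(=O)NCC3CCCO3)c2C(N)=O)C1`: > 25000 nM (a limit of the assay, not a number)

Compound 2 has no exact value and stands at the limit of > 25000 nM in this assay, at which 1 of the 2 values shown sits. Compound 3 `CCN1CCc2c(sc(NC(=O)Nc3ccc(Cl)cc3)c2C(N)=O)C1` keeps the shared core and changes one group: 4-chlorophenyl in place of (oxolan-2-yl)methyl on an amide-type nitrogen. In words, this is 4-chlorophenyl in place of (oxolan-2-yl)methyl on an amide-type nitrogen.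

Among the compounds with values here, only one measured step bears on this change. It is an at least 1.4-fold higher number from compound 1 to compound 2 (0.15 log units; that floor lies within the scatter), with (oxolan-2-yl)methyl in place of 2,3-dichlorophenyl on an amide-type nitrogen. That step is small on the evidence available, so only a modest move toward a lower number is expected, and it may not pass beyond the scatter. The entering 4-chlorophenyl resembles the 2,3-dichlorophenyl of compound 1, so 17400 nM from compound 1 is the best guide.

The expected change is an at least 1.3-fold lower number from compound 2 to compound 3 (0.14 log units; that floor lies within the scatter). For compound 3, the estimated value is 18000 nM, with an expected range of 8000 nM to 30000 nM.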

Compound 3, half-maximal effective concentration: 3120 nM
For compound 3 the middle estimate is 5.8-fold (0.76 log units) above the measured one; the whole stated range lies above it.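

In this assay, putting 4-chlorophenyl in place of (oxolan-2-yl)methyl on the amide-type nitrogen gives an at least 8.0-fold lower number from compound 2 to compound 3 (0.90 log units; beyond the scatter), so this site clearly responds to the group it carries, which the earlier step, lying within the scatter, could not show. That step is only a floor, as compound 2 carries a limit of the assay and not a number: the limit of > 25000 nM in this assay, at which 1 of the 3 values shown sits. The two chlorine-bearing phenyl groups also prove not to be interchangeable: 4-chlorophenyl in place of 2,3-dichlorophenyl gives a 5.6-fold lower number from compound 1 to compound 3 (0.75 log units; beyond the scatter), so the pattern of chlorine on the phenyl ring matters here, and compound 1 does not stand in for compound 3.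

The compounds shown leave open whether that gain comes from having one chlorine fewer or from where the remaining chlorine sits, a question that plain phenyl or 3-chlorophenyl on the same nitrogen would help to settle. They also leave open whether chlorine itself is needed, as 4-fluorophenyl or 4-methoxyphenyl would test, and whether the ring must sit directly on the nitrogen, as 4-chlorobenzyl would test.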